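This account rests on a few compounds, and the source may have more. Where it says the series, first, only, none or still open, it means among the compounds named here.

Measured so far in a functional assay on HepG2 cells (Homo sapiens) for cytotoxicity, read by MTT assay, with a stated time of 72 h; on this read-out higher numbers stand for weaker inhibition and lower numbers for stronger inhibition:
compound 1 `CN1CCN(CCCCOc2c(OCc3ccccc3)cc(O)c3c(=O)cc(-c4ccccc4)oc23)CC1` — 1500 nM
compound 2 `CN1CCN(CCCCOc2c(OCc3ccco3)cc(O)c3c(=O)cc(-c4ccccc4)oc23)CC1` — 4110 nM

Among the compounds with values here, compound 2 holds the highest of the two numbers; the only neighbour is compound 1, reached by a 2.7-fold higher number from compound 1 to compound 2 (0.44 log units; beyond the scatter). Compound 3 `CN1CCN(CCCCOc2c(OCc3nc4ccccc4s3)cc(O)c3c(=O)cc(-c4ccccc4)oc23)CC1` differs from compound 2 by 1,3-benzothiazol-2-yl in place of furan-2-yl on a saturated chain carbon bound to an oxygen on an aromatic ring. No measured step covers this change; the one step shown, from compound 1 to compound 2, concerns a different substituent at the same place and was modest. Compound 3 is therefore expected to land close to the two measured values, with a 1.6-fold lower number from compound 2 to compound 3 (0.22 log units; within the scatter) as the estimated step. The estimate for compound 3 is 2500 nM, range 900 nM to 7000 nM.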

Compound 3, half-maximal inhibitory concentration: 5440 nM
For compound 3 the middle estimate is 2.2-fold (0.34 log units) below the measured one; the measured number falls inside the stated range.
By their numbers in this assay, from the lowest: compound 1; then compounds 2 and 3 (each within the scatter of the next).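

In this assay, 1,3-benzothiazol-2-yl and furan-2-yl are not separated on the saturated chain carbon, with a 1.3-fold higher number from compound 2 to compound 3 (0.12 log units; within the scatter) as the step. The larger ring system therefore does not return the number to that of the phenyl compound, as a 3.6-fold higher number from compound 1 to compound 3 (0.56 log units; beyond the scatter) stands beyond the scatter and on the same side as a 2.7-fold higher number from compound 1 to compound 2 (0.44 log units; beyond the scatter) in this three-compound set. No measurement here bears on the reason for this.

Open, going by these compounds, is how a phenyl ring carrying a methoxy group or a chlorine would compare at this place. Also open, on these data alone, is how a saturated ring such as cyclohexyl would compare.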